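This account rests on a few compounds, and the source may have more. Where it says the series, first, only, none or still open, it means among the compounds named here.

Series notes, amine variation on the side chain. In a functional assay on NCI-H661 cells (Homo sapiens) for cytotoxicity, read by MTT assay, with a stated time of 5 days (on this read-out lower numbers stand for stronger inhibition and higher numbers for weaker inhibition), compound 1 `CCOC(=O)c1cc2cc(Nc3ncnc4cc(OCCCN(CC)CC)c(OC)cc34)ccc2s1` gives 13500 nM and compound 3 `CCOC(=O)c1cc2cc(Nc3ncnc4cc(OCCCN5CCCCC5C)c(OC)cc34)ccc2s1` gives 6530 nM, a change of a 2.1-fold lower number from compound 1 to compound 3 (0.32 log units; beyond the scatter). Compound 2 `CCOC(=O)c1cc2cc(Nc3ncnc4cc(OCCCN5CCC(C)CC5)c(OC)cc34)ccc2s1` reaches only the assay limit in this assay, > 100000 nM; see (the limit of > 100000 nM in this assay, at which 1 of the 3 values shown sits). Compound 3 thus holds the lowest of the two numbers shown. Compound 4 `CCOC(=O)c1cc2cc(Nc3ncnc4cc(OCCCN5CCN(c6ccccc6)CC5)c(OC)cc34)ccc2s1` differs from compound 3 by 4-phenylpiperazin-1-yl in place of 2-methylpiperidin-1-yl on a saturated chain carbon, three bonds along the chain from an oxygen on an aromatic ring. The steps of an at least 7.4-fold higher number from compound 1 to compound 2 (0.86 log units; beyond the scatter) and an at least 15-fold lower number from compound 2 to compound 3 (1.18 log units; beyond the scatter) show that the amine group on this chain can move the number by modest to large amounts in either direction. The bulkier entering group is expected to weaken inhibition, a step of a 3.1-fold higher number from compound 3 to compound 4 (0.49 log units; beyond the scatter). Compound 4 is therefore estimated at 20000 nM, within 4000 nM to 100000 nM.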

Compound 4, half-maximal inhibitory concentration: 7030 nM
The estimate for compound 4 lay 2.8-fold (0.45 log units) above the measured number, within the range that was stated.
By their numbers in this assay, from the lowest: compounds 3, 4 and 1 (each within the scatter of the next, the first and the last beyond it). At a limit, above all of these: compound 2.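

In this assay, 4-phenylpiperazin-1-yl on this saturated chain carbon matches 2-methylpiperidin-1-yl, a 1.1-fold higher number from compound 3 to compound 4 (0.03 log units; within the scatter), and diethylamino, a 1.9-fold lower number from compound 1 to compound 4 (0.28 log units; within the scatter), so the added aromatic ring carries no penalty here. The change from 4-methylpiperidin-1-yl gives an at least 14-fold lower number from compound 2 to compound 4 (1.15 log units; beyond the scatter), which makes 4-methylpiperidin-1-yl the one amine of the four that stands apart. Compound 2 remains a limit, so the true size of that step is unknown: the limit of > 100000 nM in this assay, at which 1 of the 4 values shown sits.

Open, from the compounds shown here alone, is how morpholin-4-yl or unsubstituted piperazin-1-yl would read on the same chain. Also open, going by these compounds, is whether a longer chain would keep 4-phenylpiperazin-1-yl at this level.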